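The compounds below may be only part of what the source reports. "The series", "measured", "known", "first", "only" and "open" are said of these compounds alone.

Compound 1 `COc1ccc(-c2nn(-c3ccccc3)cc2C(Nc2nc3ccccc3s2)c2c(O)ccc3ccccc23)cc1` and compound 2 `O=[N+]([O-])c1ccc(-c2nn(-c3ccccc3)cc2C(Nc2nc3ccccc3s2)c2c(O)ccc3ccccc23)cc1` share one core and differ in a single place; compound 3 `O=[N+]([O-])c1cccc(-c2nn(-c3ccccc3)cc2C(Nc2nc3ccc(Cl)cc3s2)c2c(O)ccc3ccccc23)c1` is built on a second core, and compound 4 `COc1cccc(-c2nn(-c3ccccc3)cc2C(Nc2nc3ccc(Cl)cc3s2)c2c(O)ccc3ccccc23)c1` is its counterpart, not yet measured. In a functional assay on HeLa cells (Homo sapiens) for antiproliferative activity, read by MTT assay, with a stated time of 48 h (on this read-out lower numbers stand for stronger inhibition and higher numbers for weaker inhibition), compound 1 gives 9340 nM, compound 2 gives 6810 nM and compound 3 gives 15500 nM. The change from compound 2 to compound 1 is methoxy in place of nitro on an aromatic carbon; it made a 1.4-fold higher number from compound 2 to compound 1 (0.14 log units; within the scatter). The difference between the core of compound 2 and the core of compound 3 is not broken down here. The change from compound 3 to compound 4 is methoxy in place of nitro on an aromatic carbon; it is the same kind of change as that from compound 2 to compound 1, but the group enters meta to a large group in compound 4 where it enters para to a large group in compound 1. The change is expected to make a step of about the earlier size, a 1.2-fold higher number from compound 3 to compound 4 (0.06 log units; within the scatter), since a 1.4-fold higher number from compound 2 to compound 1 (0.14 log units; within the scatter) lies within the scatter. Compound 4 is therefore estimated at 18000 nM, between 8000 nM and 40000 nM.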

Compound 4, half-maximal inhibitory concentration: 30000 nM
The estimate for compound 4 lay 1.7-fold (0.22 log units) below the measured number, within the range that was stated.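

In this assay, going from 3-nitrophenyl to 3-methoxyphenyl gives a 1.9-fold higher number from compound 3 to compound 4 (0.29 log units; within the scatter), so methoxy in place of nitro stays within the scatter on the second core, as it does on the first. For the compounds shown here, the change carries across these two cores without a detectable difference in step size: the same change on two cores in this assay, a 1.4-fold higher number (0.14 log units; within the scatter) from compound 2 to compound 1 and a 1.9-fold higher number (0.29 log units; within the scatter) from compound 3 to compound 4, 1.4-fold (0.15 log units) apart, within the scatter of two such steps This does not show that the step is independent of the core, since only two cores are compared, the position of the group also differs between the two pairs, and neither step is large enough to show an effect of the change itself.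

Open, from the compounds shown here alone, is how an amine or a carboxylic acid in the same place would read in this assay, and whether any replacement there would give a step beyond the scatter. Also open, going by these compounds, is whether nitro and methoxy would give the same step if the position were held fixed and only the core differed.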